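This account rests on a few compounds, and the source may have more. Where it says the series, first, only, none or still open, it means among the compounds named here.

In a functional assay on CRL2813 cells (Homo sapiens) for cytotoxicity, read by sulforhodamine B assay, with a stated time of 5 days (on this read-out lower numbers stand for stronger inhibition and higher numbers for weaker inhibition), compound 2 (`O=C(Nc1ccccc1[N+](=O)[O-])N[C@H]1CC[C@H](Oc2ccc(F)cc2)CC1`) gives 3500 nM and compound 3 (`O=C(Nc1cccc(C(F)(F)F)c1)N[C@H]1CCC[C@H](Oc2ccc(C(F)(F)F)cc2)C1`) gives 3800 nM, two values within the usual scatter of each other. Compound 1 (`O=C(Nc1ccccc1C(=O)O)N[C@H]1CC[C@@H](Oc2ccc(F)cc2)CC1`) gives only a limit of the assay, > 20000 nM, and not a number. Compound 4 (`O=C(Nc1cccc(Br)c1)N[C@H]1CC[C@H](Oc2ccc(F)cc2)CC1`) has not yet been measured. It carries 3-bromophenyl in place of 2-nitrophenyl on an amide-type nitrogen. Among the measured compounds shown here, no measured pair isolates this change, so the expectation rests on little. Compound 3, with a different group on its amide-type nitrogen, gives 3800 nM, so no shift beyond the scatter is expected in this assay. The expected step is small: a 1.2-fold lower number from compound 2 to compound 4 (0.07 log units; within the scatter). For compound 4 the estimated value is 3000 nM, with an expected range of 1200 nM to 9000 nM.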

Compound 4, half-maximal inhibitory concentration: 6200 nM
Estimate against measurement, compound 4: 2.1-fold (0.32 log units) below; the range from low to high includes it.
By their numbers in this assay, from the lowest: compounds 2, 3 and 4 (each within the scatter of the next). At a limit, above all of these: compound 1.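

In this assay, among the compounds shown here, this is the first pair that differs in only one place: putting 3-bromophenyl in place of 2-nitrophenyl on the amide-type nitrogen gives a 1.8-fold higher number from compound 2 to compound 4 (0.25 log units; within the scatter). The two compounds therefore cannot be told apart, which shows that the nitro-bearing group is not needed for cytotoxicity at this level in this series. Nothing measured here bears on why the two groups give such similar results.

From the compounds shown here alone, it remains open whether an amine or a methoxy group in place of the bromine would give a similar value.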